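Aryl swap on a fused bicyclic core: compound 1 to compound 4

This account rests on a few compounds, and the source may have more. Where it says the series, first, only, none or still open, it means among the compounds named here.

Measured so far:
- compound 1, `C=CC(=O)N1C(=O)CC(c2cccc(Cl)c2)Sc2ccccc21`: 77500 nM
- compound 2, `C=CC(=O)N1C(=O)CC(c2ccc(C(=O)OC)cc2)Sc2ccccc21`: 79600 nM
- compound 3, `C=CC(=O)N1C(=O)CC(c2ccc(-c3ccccc3)cc2)Sc2ccccc21`: 97500 nM

Three compounds share one core and differ only in the aryl group attached to a saturated ring carbon. In a functional assay on MOLT-4 cells (Homo sapiens) for cytotoxicity, read by CCK-8 assay, with a stated time of 24 h (on this read-out lower numbers stand for stronger inhibition and higher numbers for weaker inhibition), compound 1 gives 77500 nM, the lowest of the three numbers, yet its gaps to compound 2 and to compound 3 are both within the scatter, so the three cannot be told apart on these data.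

The unmeasured compound 4, `C=CC(=O)N1C(=O)CC(c2cccs2)Sc2ccccc21`, differs from compound 1 as follows: thiophen-2-yl in place of 3-chlorophenyl on a saturated ring carbon. Going by the values given here, the only measured step that bears on an aryl swap at this position is a 1.2-fold higher number from compound 2 to compound 3 (0.09 log units; within the scatter), which was within the scatter. Among the compounds with values here, nothing here indicates that any aryl group changes the number beyond the scatter, and no step involving a five-membered heteroaromatic ring has been measured.

Compound 4 is therefore expected to stay close to compound 1, with an estimated step of a 1.1-fold higher number from compound 1 to compound 4 (0.04 log units; within the scatter). The estimate for compound 4 in this assay is 85000 nM, with an expected range from 40000 nM to 180000 nM.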

Compound 4, half-maximal inhibitory concentration: 557000 nM
Estimate against measurement, compound 4: 6.6-fold (0.82 log units) below, outside the stated range (above it).
By their numbers in this assay, from the lowest: compounds 1, 2 and 3 (each within the scatter of the next); then compound 4.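

In this assay, thiophen-2-yl in place of 3-chlorophenyl on the saturated ring carbon next to the ring sulfur gives a 7.2-fold higher number from compound 1 to compound 4 (0.86 log units; beyond the scatter), which means weaker inhibition. The aryl groups of compound 1, compound 2 and compound 3 gave numbers within the scatter of one another, so this position looked tolerant of aryl swaps; compound 4 shows that the choice of ring here can matter. Nothing measured here explains the step.

From the compounds shown here alone, it remains open whether the change follows from the ring sulfur, the smaller ring or the missing chlorine, and an unsubstituted phenyl or a furan-2-yl group on this carbon would help separate these. Also open, going by these compounds, is how a non-aromatic group, such as a simple alkyl chain or an aminomethyl group, would behave at this position.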